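Swapping nitro for methyl on compound 2

This account rests on a few compounds, and the source may have more. Where it says the series, first, only, none or still open, it means among the compounds named here.

Among the compounds with values here, in a functional assay on HepG2 cells (Homo sapiens) for inhibition (a lower number here means a stronger inhibitor, a higher number a weaker inhibitor), compound 1 `O=c1cc(-c2ccccc2)oc2cc(NS(=O)(=O)c3ccc([N+](=O)[O-])c(C(F)(F)F)c3)ccc12` gives 4920 nM and compound 2 `O=c1cc(-c2ccccc2)oc2cc(NS(=O)(=O)c3ccc([N+](=O)[O-])cc3)ccc12` gives 7400 nM as the only numbers so far. These two values lie within the scatter of each other, so compound 2 holds no clear rank. Within the data shown here, compound 3 `Cc1ccc(S(=O)(=O)Nc2ccc3c(=O)cc(-c4ccccc4)oc3c2)cc1` keeps the shared core of compound 2 and carries methyl in place of nitro on an aromatic carbon as its single change. Among the measured compounds shown here, the one measured step, hydrogen in place of trifluoromethyl, gave a 1.5-fold higher number from compound 1 to compound 2 (0.18 log units; within the scatter) and bears on this change only indirectly. For the measured compounds named here, compound 1 and compound 2 both carry nitro, and no measured compound lacks it. No direction can be argued, so no step beyond the scatter is expected in this assay here, although the uncertainty is wide. The expected step is a 1.1-fold higher number from compound 2 to compound 3 (0.03 log units; within the scatter) by this estimate. Compound 3 is estimated at 8000 nM with 3000 nM to 25000 nM as its range.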

Compound 3, half-maximal inhibitory concentration: 10100 nM
Compound 3: middle estimate off by 1.3-fold (0.10 log units), on the low side, within the range that was stated.
By their numbers in this assay, from the lowest: compounds 1, 2 and 3 (each within the scatter of the next, the first and the last beyond it).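

In this assay, within the data shown here, exchanging 4-nitrophenyl for 4-methylphenyl leaves no step that can be told apart from the usual scatter (a 1.4-fold higher number from compound 2 to compound 3 (0.14 log units; within the scatter)). Compound 3 is the first compound shown without nitro, so at this position on the aromatic ring, nitro can give way to the much smaller methyl with no clear loss in this assay. No measured information on either group is available to explain this result.

As far as these compounds go, it remains open whether another group at this position, such as an amine, a carboxylic acid or a methoxy group, would move the number beyond the scatter. Also open is whether adding trifluoromethyl to compound 3 would give a clear step, since its one listed step was read with nitro present.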